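This account rests on a few compounds, and the source may have more. Where it says the series, first, only, none or still open, it means among the compounds named here.

Measured so far in an ADME assay on Vero cells (Chlorocebus sabaeus) for cytotoxicity, read by MTT assay, with a stated time of 72 h; a higher number here means a weaker inhibitor, a lower number a stronger inhibitor:
- compound 1 `COc1ccc(C(=O)C2Cc3cc(OC)c(OC)cc3C2=O)cc1`: 62.5 ug/mL
- compound 2 `COc1cc2c(cc1OC)C(=O)C(C(=O)c1ccc(Cl)cc1)C2`: 62.5 ug/mL
- compound 3 `COc1cc2c(cc1OC)C(=O)C(C(=O)c1cc(OC)c(OC)c(OC)c1)C2`: 62.5 ug/mL

Compound 2 stands level with compounds 1 and 3 on the numbers shown; none of the three is separated from another beyond the scatter. Within the data shown here, the only step measured within one place, no change at the digits printed from compound 1 to compound 2 (within the scatter), left the reading unchanged, and compound 3 sits with the others as well. Compound 4 `COc1cc2c(cc1OC)C(=O)C(C(=O)c1ccccc1Cl)C2` differs from compound 2 by 2-chlorophenyl in place of 4-chlorophenyl on a carbonyl carbon. Among the measured compounds shown here, no measured step covers a rearrangement of this kind, so the expectation rests on the flat picture across compounds 1, 2 and 3. The step from compound 2 to compound 4 in this assay is therefore expected to be no change at the digits printed from compound 2 to compound 4 (within the scatter), nothing beyond the scatter. Compound 4 is estimated at 62.5 ug/mL, within 31 ug/mL to 125 ug/mL.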

Compound 4, half-maximal inhibitory concentration: 62.5 ug/mL
Beside the measured number, compound 4's estimate shows no gap at the digits printed; the measured number falls inside the stated range.
By their numbers in this assay, from the lowest: compounds 1, 2, 3 and 4 (each within the scatter of the next).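

In this assay, 2-chlorophenyl in place of 4-chlorophenyl on the carbonyl carbon gives no change at the digits printed from compound 2 to compound 4 (within the scatter) and thus extends the flat picture to a rearrangement of the same atoms. Set against the 4-methoxyphenyl group, 2-chlorophenyl gives no change at the digits printed from compound 1 to compound 4 (within the scatter) and adds a second change at this place with no shift in the reading, with none of the compounds shown going against it. No supporting measurement bears on this result. Still open, on these data alone, is whether an amine or a carboxylic acid on the aromatic ring, or a longer chain in place of that ring, would move the reading.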